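The source may hold more compounds than are shown below. What is called first, only, known or untested is meant among the compounds shown, and "the series" means these compounds.

Working notes on the series.

Within the data shown here, the three measured members share one core and differ only in the chain and its terminal aryl group. Compound 1 `O=S(=O)(NCCCNc1nccc(-c2c(-c3cccc(F)c3)nc3sccn23)n1)c1ccc(Br)cc1` gives in a functional assay on SK-MEL-28 cells (Homo sapiens) for cytotoxicity, read by MTT assay (on this read-out lower numbers stand for stronger inhibition and higher numbers for weaker inhibition), a value of 9400 nM. Compound 2 `O=S(=O)(NCCNc1nccc(-c2c(-c3cccc(F)c3)nc3sccn23)n1)c1ccc(F)cc1` gives in this assay a value of 9450 nM. Compound 3 `O=C(NCCNc1nccc(-c2c(-c3cccc(F)c3)nc3sccn23)n1)c1ccc(C(F)(F)F)cc1` gives in this assay a value of 9260 nM. The three numbers cannot be told apart: compound 3 carries the smallest of them, but its gaps to compound 1 and compound 2 are both within the scatter, so no order among the three can be claimed.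

The next member, compound 4 `O=C(NCCNc1nccc(-c2c(-c3cccc(F)c3)nc3sccn23)n1)c1ccc(Cl)cc1`, is obtained from compound 3 by chloro in place of trifluoromethyl on an aromatic carbon. Among the measured compounds shown here, no measured step repeats this change exactly. The steps in hand, a 1.0-fold higher number from compound 1 to compound 2 (0.00 log units; within the scatter) and a 1.0-fold lower number from compound 2 to compound 3 (0.01 log units; within the scatter), each alter the terminal aryl substituent together with another part of the chain, and neither moved the number beyond the scatter. A single substituent swap on that same aryl ring is therefore expected to give no step beyond the scatter in this assay, and a 1.0-fold higher number from compound 3 to compound 4 (0.00 log units; within the scatter) is the estimated outcome.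

For compound 4 in this assay the estimate is 9300 nM, with a range of 4700 nM to 18600 nM.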

Compound 4, half-maximal inhibitory concentration: 8160 nM
Compound 4: the middle estimate sits 1.1-fold (0.06 log units) above what was measured; low and high end bracket the measured number.
By their numbers in this assay, from the lowest: compounds 4, 3, 1 and 2 (each within the scatter of the next).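

Among these compounds, this is the first step in this assay that alters only the substituent on an aromatic carbon, para to a large group, with the carbonyl and the chain held fixed: trifluoromethyl gives way to chloro, and a 1.1-fold lower number from compound 3 to compound 4 (0.05 log units; within the scatter) stays within the scatter, so at this position the two groups cannot be told apart. The wider comparisons read the same way, since a 1.2-fold lower number from compound 2 to compound 4 (0.06 log units; within the scatter) and a 1.2-fold lower number from compound 1 to compound 4 (0.06 log units; within the scatter) also lie within the scatter, although the first of these also exchanges the sulfonyl for a carbonyl and the second exchanges that linkage and alters the chain as well. No measured evidence bears on what lies behind these numbers.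

With no step among the four compounds beyond the scatter, and with the shared core the same in all of them, the compounds shown do not reveal which part of the structure, if any, governs the number. On these data alone, whether an amine or a carboxylic acid on this aromatic carbon, or a longer chain carrying the amide, would give a step beyond the scatter remains open.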